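Cyclohexyl amide in place of hydroxyphenyl: toxicity outlook

The source may report more compounds than this note shows. Statements on the series, on what has been measured and on what is new or still open speak of the compounds shown alone.

Compound 3 `COc1ccc(-c2cnc(NC(=O)c3cccc(O)c3)n2C)cc1` is one of three amides built on a shared core. In a toxicity assay on THP-1 cells (Homo sapiens) for inhibition (on this read-out lower numbers stand for higher toxicity in this test and higher numbers for lower toxicity in this test), compound 3 gives > 100000 nM, which is a limit of the test rather than a measured number. Compound 1 `COc1ccc(-c2cnc(NC(=O)c3cccc([N+](=O)[O-])c3)n2C)cc1` carries a nitro group where compound 3 carries a hydroxy; in this assay compound 1 gives > 100000 nM, again only a limit. Compound 2 `COc1ccc(-c2cnc(NC(=O)c3ccc(O)cc3)n2C)cc1` carries a 4-hydroxyphenyl on the carbonyl carbon; in this assay compound 2 gives > 100000 nM, also a limit. The two measured steps, a step that the two limits leave unreadable from compound 1 to compound 3 and a step that the two limits leave unreadable from compound 2 to compound 3, cannot be sized because of the limit of > 100000 nM in this assay, at which 3 of the 3 values shown sit. Compound 4 `COc1ccc(-c2cnc(NC(=O)C3CCCCC3)n2C)cc1` differs from compound 3 by cyclohexyl in place of 3-hydroxyphenyl on a carbonyl carbon. Among the measured compounds shown here, no measured step speaks directly to this exchange, and nothing among the three measured amides shows a toxicity the test could read. The step from compound 3 to compound 4 is therefore expected to be a step that the limit leaves unreadable from compound 3 to compound 4. For compound 4 the estimate in this assay is 150000 nM, with a range from 60000 nM to 400000 nM, and most likely once more only a limit.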

Compound 4, half-maximal cytotoxic concentration: > 100000 nM
Compound 4: no number, only a limit; the forecaster's own chance of this, stated with the estimate: 80%; the middle value lies beyond the limit too.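

Among the compounds shown here, neither the step from compound 3 to compound 4 nor the one from compound 2 to compound 4 can be read, since both ends of each are limits: the limit of > 100000 nM in this assay, at which 4 of the 4 values shown sit. The compounds shown leave open whether any amide on the shared core reaches a toxicity that this assay can express as a number.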